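Swapping a Ring Amide for an Open-Chain Hydroxyethyl Amide

This account rests on a few compounds, and the source may have more. Where it says the series, first, only, none or still open, it means among the compounds named here.

Compound 1 `COc1cc2c(cc1OC)C(CC(=O)NC(C)C)CC2`: 30%
Compound 2 `COc1cc2c(cc1OC)C(CC(=O)N1CCOCC1)CC2`: 23.3%

In a functional assay on the whole organism (strain Wistar) for inhibition, with Rattus norvegicus as the target, read by paw edema, with stated times of 60 min and 24 h, at a dose of 100 mg/kg by the oral route (on this read-out lower numbers stand for less inhibition and higher numbers for more inhibition at the one dose given (going by the name of the read-out)), compound 1 gives 30%, while compound 2 gives 23.3%, the lower of the two numbers; the step of a number 6.7 percentage points lower from compound 1 to compound 2 (within the scatter) lies within the scatter, so the pair cannot be told apart. Compound 3 `COc1cc2c(cc1OC)C(CC(=O)NCCO)CC2` differs from compound 2 by (2-hydroxyethyl)amino in place of morpholin-4-yl on a carbonyl carbon. For the measured compounds named here, the one step on record, a number 6.7 percentage points lower from compound 1 to compound 2 (within the scatter), exchanged an open-chain amine for morpholin-4-yl without a change beyond the scatter, so returning to an open-chain amine is expected to move the read-out only slightly, a number 3.7 percentage points higher from compound 2 to compound 3 (within the scatter). Compound 3 is therefore estimated at 27%, between 14% and 40%.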

Compound 3, a percentage reported as inhibition, in the whole organism at one dose (the size of the read-out at that dose, not a potency): 13.3%
Beside the measured number, compound 3's estimate is 13.7 percentage points above it; measured number outside the range, below it.
By their numbers in this assay, from the lowest: compounds 3, 2 and 1 (each within the scatter of the next, the first and the last beyond it).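

For the compounds shown here, on an amide-type nitrogen, this is the first change that clears the scatter: in this assay, 2-hydroxyethyl in place of isopropyl gives a number 16.7 percentage points lower from compound 1 to compound 3 (beyond the scatter). Exchanging morpholin-4-yl for (2-hydroxyethyl)amino on the carbonyl carbon gives a smaller step, a number 10 percentage points lower from compound 2 to compound 3 (within the scatter). No measurement here offers an explanation for either step.

As far as these compounds go, it remains open whether the hydroxyl group or simply the loss of isopropyl matters, which a plain ethyl group on that nitrogen could help separate. A longer chain, such as 3-hydroxypropyl, is also untested among the compounds shown here.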